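The source may hold more compounds than are shown below. What is called first, only, known or untested is meant among the compounds shown, and "the series" means these compounds.

Of the compounds shown here, three have numbers so far in a functional assay on HepG2 cells (Homo sapiens) for cytotoxicity, read by MTT assay, with a stated time of 48 h (on this read-out lower numbers stand for stronger inhibition and higher numbers for weaker inhibition), on this scale. Compound 1 (`CC1=NN(C(=O)CCl)C(c2cc(Br)ccc2O)C1`) gives 16300 nM there, compound 2 (`CC(=O)Oc1ccccc1C1CC(C)=NN1C(=O)CN1CCCCC1`) gives 19000 nM and compound 3 (`O=C(c1ccccc1)N1N=C(c2cc3ccccc3oc2=O)CC1c1ccccc1`) gives 36600 nM as the highest of the three numbers. That position is only partly firm: the gap between compound 3 and compound 2 stays within the usual scatter of repeated measurements, and only the gap to compound 1 goes beyond it.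

Compound 4 (`CCNCC(=O)N1N=C(c2cc3ccccc3oc2=O)CC1c1ccccc1`) is compound 3 with a single change, (ethylamino)methyl in place of phenyl on a carbonyl carbon so that benzoyl becomes ((ethylamino)methyl)carbonyl. Among the compounds with values here, no measured pair shows this kind of swap, so any forecast is loose. Within the data shown here, the only hint is compound 2, which also carries an amine on the group attached to its carbonyl and reads 19000 nM on a different core. On that thin basis, a small move toward a lower number is expected, one that stays within the scatter. The estimate reads a 1.7-fold lower number from compound 3 to compound 4 (0.22 log units; within the scatter) and remains only an expectation. In this assay the estimated value for compound 4 is 22000 nM and the expected range runs from 8000 nM to 60000 nM on that read-out.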

Compound 4, half-maximal inhibitory concentration: 30600 nM
For compound 4 the middle estimate is 1.4-fold (0.14 log units) below the measured one; the range from low to high includes it.
By their numbers in this assay, from the lowest: compounds 1, 2, 4 and 3 (each within the scatter of the next, the first and the last beyond it).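

In this assay the step reads a 1.2-fold lower number from compound 3 to compound 4 (0.08 log units; within the scatter) and so, as far as this read-out can tell, putting (ethylamino)methyl in place of phenyl on this carbonyl carbon leaves the number unchanged. Within the data shown here, this is the first pair here that differs in only one place, and it shows that benzoyl can become ((ethylamino)methyl)carbonyl, losing an aromatic ring and gaining a nitrogen with a hydrogen-bond donor and acceptor, without a shift beyond the usual scatter. Nothing available offers an explanation for why the two compounds read alike.

A single swap cannot show whether any group on this carbonyl carbon would move the number, so a morpholine, a carboxylic acid or a longer carbon chain in the same place remains an open case. The rest of the shared core is also identical in compound 3 and compound 4, which leaves open what a change elsewhere, such as a fluorine on its phenyl group, would do in this assay on this scale.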